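Swapping Nitro for Bromo on the Aromatic Ring

This account rests on a few compounds, and the source may have more. Where it says the series, first, only, none or still open, it means among the compounds named here.

Measured in an ADME assay on cells (Peritoneal macrophage, Mus musculus) for cytotoxicity, read by MTT assay, with a stated time of 24 h; on this read-out higher numbers stand for lower toxicity in this test and lower numbers for higher toxicity in this test:
- Compound 1 `CC(C)(C)c1ccc(N/C(=N\C(=O)c2ccccc2)NCc2ccccc2)cc1`: 1120000 nM
- Compound 2 `O=C(/N=C(/NCc1ccccc1)Nc1ccc([N+](=O)[O-])cc1)c1ccccc1`: 802000 nM

Compound 2 holds the lower of these two numbers, but only just: nitro in place of tert-butyl on an aromatic carbon gives a 1.4-fold lower number from compound 1 to compound 2 (0.15 log units; within the scatter). Compound 3 `O=C(/N=C(/NCc1ccccc1)Nc1ccc(Br)cc1)c1ccccc1` carries bromo in place of nitro on that same aromatic carbon: bromo in place of nitro on an aromatic carbon. Among the compounds with values here, this is the only measured step that bears on the change, and since it amounts to just a 1.4-fold lower number from compound 1 to compound 2 (0.15 log units; within the scatter), no step beyond the scatter is expected in this assay. The expected step is a 1.1-fold higher number from compound 2 to compound 3 (0.05 log units; within the scatter). For compound 3 the estimated value is 900000 nM, with an expected range of 450000 nM to 1800000 nM.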

Compound 3, half-maximal cytotoxic concentration: 738000 nM
Compound 3: the middle estimate sits 1.2-fold (0.09 log units) above what was measured, within the range that was stated.
By their numbers in this assay, from the lowest: compounds 3, 2 and 1 (each within the scatter of the next).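

Bromo in place of nitro gives a 1.1-fold lower number from compound 2 to compound 3 (0.04 log units; within the scatter) and bromo in place of tert-butyl gives a 1.5-fold lower number from compound 1 to compound 3 (0.18 log units; within the scatter) in this assay, so all three compounds lie within the scatter of one another. With a third group at this aromatic carbon, the position has still shown no step beyond the scatter on this read-out. No measurement here explains why these groups read alike. On these data alone, whether an amine or a carboxylic acid on this carbon would read the same remains open, as does how the same groups would behave elsewhere on the shared core.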